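A few compounds are considered here, and "the series" means these few. Any claim that something is new, unique, unknown or untested is made for them only; others in the source may bear on it.

Measured in a functional assay on OVCAR-3 cells (Homo sapiens) for antiproliferative activity, read by spectrophotometry, with a stated time of 2 days; a higher number here means a weaker inhibitor of growth, a lower number a stronger inhibitor of growth:
- Compound 1 `COc1cc(Nc2ncc(C(F)(F)F)c(N3Cc4cccc(N(C)S(C)(=O)=O)c4C3)n2)cc(OC)c1`: 630 nM
- Compound 2 `COc1cc(Nc2ncc(C(F)(F)F)c(N3Cc4cccc(N(C)S(C)(=O)=O)c4C3)n2)cc(C(F)(F)F)c1`: > 30000 nM (a limit of the assay, not a number)

Compound 2 stands at the far weak end of the numbers shown, with the limit of > 30000 nM in this assay, at which 1 of the 2 values shown sits. Compound 3 `CN(c1cccc2c1CN(c1nc(Nc3ccc(Cl)c(C(F)(F)F)c3)ncc1C(F)(F)F)C2)S(C)(=O)=O` differs from compound 2 in one place: 4-chloro-3-(trifluoromethyl)phenyl in place of 3-methoxy-5-(trifluoromethyl)phenyl on a nitrogen on an aromatic ring. The group that enters still carries a trifluoromethyl, and the methoxy is gone.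

Among the measured compounds shown here, one measured step bears on this: an at least 47-fold higher number from compound 1 to compound 2 (1.67 log units; beyond the scatter). That large step came with the loss of a methoxy, and compound 3 has lost the remaining one, so no strong recovery is expected in this assay. The number should stay high and may again reach the limit, given the step for compound 2 an at least 47-fold higher number from compound 1 to compound 2 (1.67 log units; beyond the scatter).

The expected step is small: an at least 1.5-fold lower number from compound 2 to compound 3 (0.17 log units; that floor lies within the scatter). For compound 3 the estimate is 20000 nM, with an expected range from 6000 nM to 40000 nM.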

Compound 3, concentration for 50% growth inhibition: > 50000 nM
Compound 3: no number, only a limit; the forecaster's own chance of this, stated with the estimate: 55%; at least 2.5-fold (0.39 log units) between middle value and limit.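

In this assay, 4-chloro-3-(trifluoromethyl)phenyl in place of 3,5-dimethoxyphenyl on the nitrogen gives an at least 79-fold higher number from compound 1 to compound 3 (1.89 log units; beyond the scatter), so a second replacement at this position, this one with no methoxy left and with a chlorine added, also comes with a large loss of growth inhibition. Compound 3 gives > 50000 nM, which is a limit of the assay and not a number. Compound 2 also stands at a limit, so the step from compound 2 to compound 3 cannot be read, and the two groups cannot be ranked against each other.

Going by these compounds, it stays open whether another group on this phenyl ring, such as an amine or a hydroxyl, could keep the growth inhibition seen with compound 1. The compounds shown also do not separate the effect of the chlorine from that of the trifluoromethyl in compound 3.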